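This account rests on a few compounds, and the source may have more. Where it says the series, first, only, none or still open, it means among the compounds named here.

Measured compounds:
- compound 1 `COc1cc(NC(C)CCCNC(=O)Nc2ccc(O)cc2)c2ncccc2c1` — 5200 nM
- compound 2 `COc1cc(NC(C)CCCNC(=O)NNC(=O)Nc2ccc(C(F)(F)F)cc2)c2ncccc2c1` — 100 nM

In a functional assay on MCF7 cells (Homo sapiens) for inhibition, read by MTT assay, with a stated time of 72 h (a higher number here means a weaker inhibitor, a lower number a stronger inhibitor), compound 1 gives 5200 nM, the highest of the two numbers shown. Among the measured compounds shown here, compound 2 gives 100 nM, a far lower number that lies beyond the scatter, but the two structures differ in more than one place, so no single step is drawn from them. Compound 3 `COc1cc(NC(C)CCCNC(=O)Nc2cccc(C(F)(F)F)c2)c2ncccc2c1` is unmeasured and differs from compound 1 as follows: 3-(trifluoromethyl)phenyl in place of 4-hydroxyphenyl on an amide-type nitrogen. For the measured compounds named here, no step between measured compounds covers this change, so the direction is uncertain; a moderate drop in the number is expected, a 2.9-fold lower number from compound 1 to compound 3 (0.46 log units; beyond the scatter), with wide bounds. Compound 3 is estimated at 1800 nM, between 400 nM and 7000 nM.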

Compound 3, half-maximal inhibitory concentration: 3300 nM
Beside the measured number, compound 3's estimate is 1.8-fold (0.26 log units) below it, within the range that was stated.
By their numbers in this assay, from the lowest: compound 2; then compounds 3 and 1 (each within the scatter of the next).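

At this amide-type nitrogen, 3-(trifluoromethyl)phenyl in place of 4-hydroxyphenyl gives a 1.6-fold lower number from compound 1 to compound 3 (0.20 log units; within the scatter) in this assay. This position therefore tolerates the exchange of these two aryl groups, including the loss of the hydroxyl, without a change that stands clear of the scatter in this assay. Nothing measured here bears on why the two groups read alike.

On these data alone, it remains open whether an amine or a carboxylic acid on this phenyl ring would read differently. Also open is which of its structural differences accounts for compound 2 at 100 nM.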